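A few compounds are considered here, and "the series" means these few. Any claim that something is new, unique, unknown or untested is made for them only; others in the source may bear on it.

Measured compounds in an ADME assay on MRC5 cells (Homo sapiens) for cytotoxicity, read by fluorescence and resazurin assay, with a stated time of 3 days; on this read-out higher numbers stand for weaker inhibition and lower numbers for stronger inhibition

compound 1 (`Cc1cn(C2CCN(Cc3cccc(Oc4ccccc4)n3)CC2)c(=O)[nH]c1=O`) gives > 64000 nM (a limit)
compound 2 (`Cc1cn(C2CCN(Cc3cccc(Oc4cc(Cl)cc(Cl)c4)c3)CC2)c(=O)[nH]c1=O`) gives 6730 nM
compound 3 (`Cc1cn(C2CCN(Cc3cccc(Oc4ccc(F)c(F)c4)c3)CC2)c(=O)[nH]c1=O`) gives > 64000 nM (a limit)

Compound 1 has no number in this assay, only a limit. Its position is the limit of > 64000 nM in this assay, at which 2 of the 3 values shown sit, and compound 3 shares it.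

Compound 4 (`Cc1cn(C2CCN(Cc3cccc(Oc4cccc(Cl)c4)n3)CC2)c(=O)[nH]c1=O`) differs from compound 1 by chloro in place of hydrogen on an aromatic carbon, meta to a large group (chloro in place of hydrogen on an aromatic carbon), which reads as phenoxy to 3-chlorophenoxy.

For the measured compounds named here, no measured step adds a chloro to compound 1. Going by the values given here, the only measured step, an at least 9.5-fold higher number from compound 2 to compound 3 (0.97 log units; beyond the scatter), puts 3,4-difluorophenyl in place of 3,5-dichlorophenyl, and it bears on the question only indirectly, as compound 2 and compound 3 do not share the core of compound 1. Among the three compounds, compound 2 alone carries chloro and alone gives a number, at 6730 nM in this read-out. Compound 4 carries a single chloro, so a move towards a lower number is expected, though it may not clear the limit.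

The expected change is an at least 2.1-fold lower number from compound 1 to compound 4 (0.32 log units; beyond the scatter), an estimate resting on a limit at its starting end.

For compound 4 the estimated value is 30000 nM, with an expected range of 10000 nM to 64000 nM.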

Compound 4, half-maximal inhibitory concentration: > 64000 nM
Compound 4 gave a limit, no number (the forecaster's own chance of this, stated with the estimate: 40%); middle value at least 2.1-fold (0.32 log units) from the limit.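

In this assay compound 4 gives > 64000 nM, a limit and not a number. Compound 1 gives > 64000 nM, also a limit, so the step from phenoxy to 3-chlorophenoxy cannot be read. The compounds shown leave open whether a single chloro changes this read-out at all on the core of compound 1.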